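Swapping a dimethoxyphenyl end for furan on a chalcone-like chain

The compounds below may be only part of what the source reports. "The series", "measured", "known", "first", "only" and "open" are said of these compounds alone.

Measured so far:
Compound 1, `COc1cc(/C=C/C(=O)/C=C/c2ccccc2)ccc1OCc1cn(CCCOc2cc(=O)oc3ccccc23)nn1`: 48%
Compound 2, `COc1ccccc1/C=C/C(=O)/C=C/c1ccc(OCc2cn(CCCCOc3cc(=O)oc4ccccc34)nn2)c(OC)c1`: 40%
Compound 3, `COc1ccc(/C=C/C(=O)/C=C/c2ccc(OCc3cn(CCOc4cc(=O)oc5ccccc45)nn3)c(OC)c2)cc1OC`: 90%

In a functional assay on THP-1 cells (Homo sapiens) for inhibition, read by sulforhodamine B assay, with a stated time of 48 h, tested at 50 uM (on this read-out lower numbers stand for less inhibition of growth and higher numbers for more inhibition of growth at the one concentration tested), compound 3 gives 90%, the highest of the three numbers. Compound 1 gives 48% and compound 2 gives 40%; both lie below compound 3 by gaps beyond the usual scatter, so compound 3 stands clearly apart from the other two on this read-out. Compound 1 and compound 2 lie within the scatter of each other, and nothing separates them here.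

Compound 4, `COc1cc(/C=C/C(=O)/C=C/c2ccco2)ccc1OCc1cn(CCOc2cc(=O)oc3ccccc23)nn1`, has not yet been measured. It differs from compound 3 in one place: furan-2-yl in place of 3,4-dimethoxyphenyl on a double-bonded chain carbon bound to a double-bonded chain carbon. Both compounds carry the same two-carbon linker to the coumarin side, so the change is confined to that one end of the chain.

Among the measured compounds shown here, no measured pair isolates this change. For the measured compounds named here, the only hint comes from compound 1, whose phenyl-ended chain, on a different linker, sits far below compound 3. On that basis the step of a number 35 percentage points lower from compound 3 to compound 4 (beyond the scatter) is expected to be a drop beyond the scatter. Compound 4 is therefore estimated at 55%, with a plausible range from 30% to 80%.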

Compound 4, percent growth inhibition at one concentration: 78%
For compound 4 the middle estimate is 23 percentage points below the measured one; the range from low to high includes it.
By their numbers in this assay, from the lowest: compounds 2 and 1 (each within the scatter of the next); then compound 4; then compound 3.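

In this assay, replacing 3,4-dimethoxyphenyl with furan-2-yl on a double-bonded chain carbon bound to a double-bonded chain carbon gives a number 12 percentage points lower from compound 3 to compound 4 (beyond the scatter), the only direct reading of this position among the compounds shown. The change is real but modest, and it shows that this end of the chain tolerates a group of 5 heavy atoms with 1 hydrogen-bond acceptor in place of one of 10 heavy atoms with 2, with only part of the growth inhibition lost. Nothing available explains the step.

The pair cannot separate the effect of the ring from that of the two methoxy groups, and a thiophen-2-yl or a plain phenyl on this same two-carbon linker would bear on that. Going by these compounds, whether furan-2-yl gives a similar step on the longer linkers of compound 1 and compound 2 also remains open.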